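Counterscreen for a triazole bicyclooctane: an aryl sulfone ether

The source may hold more compounds than are shown below. What is called first, only, known or untested is meant among the compounds shown, and "the series" means these compounds.

Compound 1, `Cn1c(-c2ccccc2C(F)(F)F)nnc1C12CCC(CCS(=O)(=O)C(C)(C)C)(CC1)CC2`, in an assay on CHO-K1 cells for inhibition of 11-beta-hydroxysteroid dehydrogenase type 2 (Homo sapiens), read by scintillation proximity assay (on this read-out lower numbers stand for stronger inhibition and higher numbers for weaker inhibition), gives > 4000 nM, a limit of the assay.
Compound 2, `Cn1c(-c2ccccc2C(F)(F)F)nnc1C12CCC(CNS(C)(=O)=O)(CC1)CC2`, in this assay gives > 4000 nM, also a limit.
Compound 3, `Cn1c(-c2ccccc2C(F)(F)F)nnc1C12CCC(CCCC(C)(F)F)(CC1)CC2`, in this assay gives > 4000 nM, again a limit.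

None of the three shown compounds gives a number in this assay; compound 3 therefore stands at the same limit as the other two, and no ordering among them can be read. The steps that join them remain unreadable for the same reason: a step that the two limits leave unreadable from compound 1 to compound 2, a step that the two limits leave unreadable from compound 1 to compound 3 and a step that the two limits leave unreadable from compound 2 to compound 3. What the set does show is the limit of > 4000 nM in this assay, at which 3 of the 3 values shown sit, so varying the group on the saturated chain carbon bound to the ring carbon has not, so far, brought any compound into the measurable range.

Compound 4, `Cn1c(-c2ccccc2C(F)(F)F)nnc1C12CCC(COc3ccc(S(C)(=O)=O)cc3)(CC1)CC2`, differs from compound 3 by a group of 11 heavy atoms (7 carbon, 3 oxygen, 1 sulfur; one six-membered aromatic ring of carbon only) in place of a group of 6 heavy atoms (4 carbon, 2 fluorine; no ring), on a saturated chain carbon bound to a saturated ring carbon. For the measured compounds named here, no measured step bears directly on this exchange, since every step in the set sits between two limits. He therefore expects compound 4 to behave like compound 3, with the step that the limit leaves unreadable from compound 3 to compound 4 most likely not readable. He estimates compound 4 in this assay at 6000 nM, within 2000 nM to 30000 nM.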

Compound 4, half-maximal inhibitory concentration: > 4000 nM
Compound 4 gave a limit, no number; the forecaster's own chance of this, stated with the estimate: 75%; the middle value lies beyond the limit too.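

Compound 4 gives > 4000 nM in this assay as a limit and not a number, so its steps from compound 1, compound 2 and compound 3 cannot be read. The set stands at a single limit: the limit of > 4000 nM in this assay, at which 4 of the 4 values shown sit. The compounds shown leave open how strongly any of them inhibits the enzyme, and whether any group at this place would give a measurable value.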